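This account rests on a few compounds, and the source may have more. Where it says the series, first, only, none or still open, it means among the compounds named here.

Compound 2 `Clc1ccc(Cn2ccc3nc(-c4ccccc4)nc-3c2)cc1` is considered in an ADME assay on MDBK cells (Bos taurus) for cytotoxicity; a lower number here means that less compound is tolerated, a higher number that more compound is tolerated. In this assay compound 2 gives > 100000 nM, which is a limit and not a number. Compound 1 `Cc1ccc(Cn2ccc3nc(-c4ccccc4)nc-3c2)cc1` likewise gives > 100000 nM in this assay, again a limit. Compound 3 `CC(C)(C)c1ccc(Cn2ccc3nc(-c4ccccc4)nc-3c2)cc1` gives 22000 nM in this assay. The measured steps run a step that the two limits leave unreadable from compound 1 to compound 2, an at least 4.5-fold lower number from compound 1 to compound 3 (0.65 log units; beyond the scatter) and an at least 4.5-fold lower number from compound 2 to compound 3 (0.65 log units; beyond the scatter), and two of the three values sit at the limit of > 100000 nM in this assay, at which 2 of the 3 values shown sit. Compound 4 `CCn1ccc2nc(-c3ccccc3)nc-2c1` differs from compound 2 in that (methyl in place of 4-chlorophenyl on a saturated chain carbon bound to an aromatic nitrogen). Going by the values given here, no measured step removes the aryl part; the two readable steps went toward tert-butyl and lowered the number, whereas here the group shrinks to methyl, so no lowering is anticipated. Compound 4 is expected to stay at or past the limit, a step that the limit leaves unreadable from compound 2 to compound 4, estimated at 150000 nM with a range of 50000 nM to 500000 nM.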

Compound 4, half-maximal cytotoxic concentration: > 100000 nM
Compound 4 ended at the assay's limit; the forecaster's own chance of this, stated with the estimate: 80%; the middle value does not contradict the limit.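

In this assay compound 4 gives > 100000 nM, which is a limit, so its steps from compound 1 and compound 2, both also limits, cannot be read. The compounds shown leave open whether methyl in place of 4-chlorophenyl changes the tolerated concentration at all.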